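A few compounds are considered here, and "the series" means these few. Any claim that something is new, unique, unknown or untested is made for them only; others in the source may bear on it.

In a functional assay on the whole organism (strain Wistar) with Rattus norvegicus as the target, with a stated time of 5 min (a higher number here means that more compound is needed for the effect, a lower number that less compound is needed), compound 1 `O=C1Nc2ccc(F)cc2C1CCCCN1CCN(c2cccc(Cl)c2)CC1` gives only a limit, > 20 mg/kg. Compound 2 `CCC1(CCCCN2CCN(c3ccc(OC)cc3)CC2)C(=O)Nc2ccccc21` likewise gives only a limit in this assay, > 20 mg/kg. Both values shown thus sit at the same limit (the limit of > 20 mg/kg in this assay, at which 2 of the 2 values shown sit), so compound 2 cannot be placed relative to compound 1 on the numbers shown. Compound 3 `CCC1(CCCCN2CCN(c3ccccc3)CC2)C(=O)Nc2ccccc21` differs from compound 2 in one place: hydrogen in place of methoxy on an aromatic carbon. Going by the values given here, no measured step of this kind is at hand; the expected step from compound 2 to compound 3 is a step that the limit leaves unreadable from compound 2 to compound 3, none beyond the scatter. Compound 3 is therefore expected to give 30 mg/kg, within 12 mg/kg to 80 mg/kg, most likely again reported as a limit.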

Compound 3, minimum effective dose: 10 mg/kg
For compound 3 the middle estimate is 3.0-fold (0.48 log units) above the measured one, outside the stated range (below it).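

In this assay, going by these compounds alone, going from 4-methoxyphenyl to phenyl gives an at least 2.0-fold lower number from compound 2 to compound 3 (0.30 log units; that floor lies within the scatter), so this position para to a large group can respond to the change, and compound 3 gives a number where the earlier compounds do not. Compound 2 gives only a limit, so the size of this step remains unknown: the limit of > 20 mg/kg in this assay, at which 2 of the 3 values shown sit.

From the compounds shown here alone, whether a methyl or a hydroxyl at this place would stay at the limit or read like hydrogen remains open. So does whether the same change would act alike on a core without the ethyl group.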